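Trifluoromethyl for trifluoromethoxy in an inactive series

The source may hold more compounds than are shown below. What is called first, only, known or untested is meant among the compounds shown, and "the series" means these compounds.

Measured in a functional assay on SEM cells (Homo sapiens) for cytotoxicity, with a stated time of 72 h; a lower number here means that less compound is needed, a higher number that more compound is needed for the effect:
compound 1 `C=C[C@@](C)(/C=C/c1ccc(O)cc1)CC/C=C(\C)CO`: > 36600 nM
compound 2 `C=C[C@@](C)(/C=C/c1ccc(Nc2ccc(OC(F)(F)F)cc2)cc1)CCC=C(C)C`: > 36600 nM

Neither result is a number. Compound 1 gives > 36600 nM, which is a limit of the assay. Compound 2 gives > 36600 nM, also a limit of the assay. The record so far is therefore (the limit of > 36600 nM in this assay, at which 2 of the 2 values shown sit), and compound 2 has no measured position beyond that.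

Compound 3 `C=C[C@@](C)(/C=C/c1ccc(Nc2ccc(C(F)(F)F)cc2)cc1)CCC=C(C)C` is the next step from compound 2. It has trifluoromethyl in place of trifluoromethoxy on an aromatic carbon, para to a large group: trifluoromethyl in place of trifluoromethoxy on an aromatic carbon. The rest of the structure stays the same.

Going by the values given here, no measured pair gives the size of such a swap in this assay, so the data offer no direct guide. The expectation is no change beyond the scatter, and a further limit is the likeliest report. For compound 3 the estimated value is 36600 nM, with an expected range from 12000 nM to 60000 nM. The estimated step is a number no higher from compound 2 to compound 3 (the limit leaves the size open), which remains an expectation until the measurement is available.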

Compound 3, half-maximal effective concentration: > 36600 nM
Compound 3 ended at the assay's limit; the forecaster's own chance of this, stated with the estimate: 75%; the middle value sits exactly at the limit.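

In this assay, compound 2 and compound 3 both end at a limit of the assay, so no step can be read for the swap of trifluoromethoxy to trifluoromethyl. The compounds shown leave open whether this swap changes the effect at all, and what any member of the series gives as a true number, with the record so far standing at one value: the limit of > 36600 nM in this assay, at which 3 of the 3 values shown sit.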